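The source may hold more compounds than are shown below. What is called first, only, known or untested is meant among the compounds shown, and "the series" means these compounds.

Measured compounds:
compound 1 `CC(=O)O[C@@H]1OC(=O)[C@@](C)(C(C)=O)[C@@H]1C` gives 12000 nM in a functional assay on HT-29 cells (Homo sapiens) for cytotoxicity, read by MTT assay; a lower number here means a stronger inhibitor, a higher number a weaker inhibitor
compound 2 `CC(=O)O[C@@H]1OC(=O)[C@@](C)(C(=O)c2ccccc2)[C@@H]1C` gives 7000 nM in this assay

Compound 1 has the highest of the two numbers; its nearest neighbour is compound 2, reached by a 1.7-fold lower number from compound 1 to compound 2 (0.23 log units; within the scatter). The step to compound 3 `CC(=O)[C@]1(C)C(=O)O[C@@H](OC(=O)c2ccccc2)[C@H]1C` is phenyl in place of methyl on a carbonyl carbon. Going by the values given here, the only step with a bearing on it is the one from compound 1 to compound 2, the same exchange made at the other carbonyl carbon, which stayed within the scatter. On that basis compound 3 is expected to land near compound 1, with a 1.3-fold lower number from compound 1 to compound 3 (0.12 log units; within the scatter) as the expected step. Compound 3 is estimated at 9000 nM, within 4000 nM to 25000 nM.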

Compound 3, half-maximal inhibitory concentration: 6000 nM
For compound 3 the middle estimate is 1.5-fold (0.18 log units) above the measured one; the range from low to high includes it.
By their numbers in this assay, from the lowest: compounds 3, 2 and 1 (each within the scatter of the next).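

In this assay, placing phenyl instead of methyl on the carbonyl carbon whose other neighbour is oxygen next to a carbonyl group gives a 2.0-fold lower number from compound 1 to compound 3 (0.30 log units; within the scatter), so this position shows no difference between the two groups. The same holds at the other carbonyl carbon (a 1.7-fold lower number from compound 1 to compound 2 (0.23 log units; within the scatter)), so neither place yet separates methyl from phenyl. Nothing available offers a reason for this result.

Still open, as far as these compounds go, is whether an amine, a carboxylic acid or a longer chain on either carbonyl carbon would move the number beyond the scatter, and what phenyl on both carbonyl carbons together would give.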